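Fluorophenyl imine in place of amine: expected cytotoxicity

The source may hold more compounds than are shown below. What is called first, only, known or untested is meant among the compounds shown, and "the series" means these compounds.

Compound 1 `Nc1sc2c(c1-c1nc3ccccc3s1)CCCC2`: 475 ug/mL
Compound 2 `Fc1ccc(/C=N/c2sc3c(c2-c2nc4ccccc4s2)CCC3)cc1`: 372 ug/mL
Compound 3 `C(=C/c1ccccc1)\C=N\c1sc2c(c1-c1nc3ccccc3s1)CCC2`: 100 ug/mL

Compound 1 gives the highest number of the three in an ADME assay on HeLa cells (Homo sapiens) for cytotoxicity, read by MTT assay, with a stated time of 72 h (on this read-out lower numbers stand for higher toxicity in this test and higher numbers for lower toxicity in this test), though compound 2 sits within the scatter of it, and only compound 3 lies clearly lower. Compound 4 `Fc1ccccc1/C=N/c1sc2c(c1-c1nc3ccccc3s1)CCCC2` is compound 1 with a group of 9 heavy atoms (7 carbon, 1 nitrogen, 1 fluorine; one six-membered aromatic ring of carbon only) in place of one nitrogen atom, on an aromatic carbon. Among the compounds with values here, no measured step copies this change exactly. Compound 2 carries a related imine on a core that also differs in ring size, and its value against that of compound 1 shows no difference beyond the scatter. The step of a 3.7-fold lower number from compound 2 to compound 3 (0.57 log units; beyond the scatter) shows that the group on the imine carbon can move the number clearly, but that step swaps an aromatic ring for a phenylethenyl chain, which is not what happens here. A fluorophenyl imine is therefore expected to leave the number near that of compound 1, with the step of a 1.3-fold lower number from compound 1 to compound 4 (0.12 log units; within the scatter) estimated to stay within the scatter. The estimate for compound 4 is 360 ug/mL, in a range from 180 ug/mL to 700 ug/mL.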

Compound 4, half-maximal cytotoxic concentration: 426 ug/mL
Compound 4: middle estimate off by 1.2-fold (0.07 log units), on the low side, within the range that was stated.
By their numbers in this assay, from the lowest: compound 3; then compounds 2, 4 and 1 (each within the scatter of the next).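

In this assay, putting the fluorophenyl imine in place of the amino group on the shared core, on the aromatic carbon next to the ring sulfur, gives a 1.1-fold lower number from compound 1 to compound 4 (0.05 log units; within the scatter) and so leaves the reading within the usual scatter. Within the data shown here, this is the first comparison here in which only this position differs, and it shows that a group of 9 heavy atoms with an aromatic ring and no hydrogen-bond donor can replace the amino group without a measurable shift in this test. Nothing available explains why the reading holds.

Going by these compounds, whether the fluorine plays any part remains open, as an imine with a plain phenyl ring would be needed to show that. Also open, on these data alone, is how an acetamide or a carboxylic acid at this position would read on the core of compound 1.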